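The source may report more compounds than this note shows. Statements on the series, on what has been measured and on what is new or still open speak of the compounds shown alone.

Of the compounds shown here, three of one core have been measured. Compound 1 `O=C(Nc1ccc(-c2noc(-c3cccc(NS(=O)(=O)c4cccc(Cl)c4)c3)n2)c(Cl)c1)c1cccnc1` bears a (3-chlorophenyl)sulfonyl group on the ring nitrogen. In a functional assay on MDA-MB-231 cells (Homo sapiens) for antiproliferative activity, read by MTT assay, with a stated time of 72 h (a higher number here means a weaker inhibitor, a lower number a stronger inhibitor), compound 1 gives only a limit, > 10000 nM. Compound 2 `Cc1ccc(S(=O)(=O)Nc2cccc(-c3nc(-c4ccc(NC(=O)c5cccnc5)cc4Cl)no3)c2)cc1` likewise gives a limit in this assay, > 10000 nM. Within the data shown here, compound 3 `Cc1ccc(NC(=O)Nc2cccc(-c3nc(-c4ccc(NC(=O)c5cccnc5)cc4Cl)no3)c2)cc1`, the urea, gives in this assay the only actual number of the set, 3500 nM. The step of an at least 2.8-fold lower number from compound 1 to compound 3 (0.45 log units; beyond the scatter) and the step of an at least 2.8-fold lower number from compound 2 to compound 3 (0.45 log units; beyond the scatter) both run the same way, but both rest on (the limit of > 10000 nM in this assay, at which 2 of the 3 values shown sit), so only their lower bound is known. Compound 4 `CS(=O)(=O)Nc1ccc(NC(=O)Nc2cccc(-c3nc(-c4ccc(NC(=O)c5cccnc5)cc4Cl)no3)c2)cc1Cl` is not yet measured; it differs from compound 3 in this way: 3-chloro-4-(methanesulfonamido)phenyl in place of 4-methylphenyl on an amide-type nitrogen. The measured steps compare carbamoyl with sulfonyl on that nitrogen and say nothing about substitution of the aryl ring itself, so they bear on compound 4 only in that the urea is kept. The expected step of a 1.4-fold lower number from compound 3 to compound 4 (0.15 log units; within the scatter) is therefore small, within the scatter or a modest gain. Compound 4 is estimated at 2500 nM, between 600 nM and 10000 nM.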

Compound 4, half-maximal inhibitory concentration: 600 nM
The estimate for compound 4 lay 4.2-fold (0.62 log units) above the measured number; the range from low to high includes it.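

In this assay the aryl group on the urea proves to be a place where a change can be read, since putting 3-chloro-4-(methanesulfonamido)phenyl in place of 4-methylphenyl on the amide-type nitrogen gives a 5.8-fold lower number from compound 3 to compound 4 (0.77 log units; beyond the scatter). The earlier steps shown here compared only carbonyl with sulfonyl linkage on the ring nitrogen and gave lower bounds, whereas this step has an actual number at both ends, so its size is known. Nothing shown here gives a reason for this step.

Going by these compounds, the change brings in the chlorine and the methanesulfonamido group together, so it remains open how much of the step belongs to each, and how 3-chlorophenyl or 4-(methanesulfonamido)phenyl alone would compare on that nitrogen. Also open, on these data alone, is how an amine or a carboxylic acid on this aryl ring would fare.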